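Methyl in place of chloro: from compound 2 to compound 3

The source may hold more compounds than are shown below. What is called first, only, known or untested is meant among the compounds shown, and "the series" means these compounds.

Going by the values given here, compound 2 `COc1cc(-c2cc(-c3ccc(Cl)cc3)nc(-c3ccccc3)n2)cc(OC)c1OC` gives 6230 nM in a functional assay on HT-29 cells (Homo sapiens) for inhibition, read by MTT assay, with a stated time of 48 h; on this read-out higher numbers stand for weaker inhibition and lower numbers for stronger inhibition; of the two numbers so far, its number and that of compound 1 `COc1cc(-c2cc(-c3cccc4ccccc34)nc(-c3ccccc3)n2)cc(OC)c1OC`, which gives 4730 nM, lie within the scatter of each other, the step being a 1.3-fold higher number from compound 1 to compound 2 (0.12 log units; within the scatter). Compound 3 `COc1cc(-c2cc(-c3ccc(C)cc3)nc(-c3ccccc3)n2)cc(OC)c1OC` differs from compound 2 by methyl in place of chloro on an aromatic carbon. Among the compounds with values here, no measured step exchanges these two groups; the only step seen, a change of the aryl group at this same position, stayed within the scatter, so no step beyond the scatter is expected in this assay. Compound 3 is therefore estimated at 6000 nM, between 2500 nM and 14000 nM. The expected step of a 1.0-fold lower number from compound 2 to compound 3 (0.02 log units; within the scatter) is within the scatter.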

Compound 3, half-maximal inhibitory concentration: > 25000 nM
Compound 3 was reported as a limit; the forecaster's own chance of this, stated with the estimate: 5%; middle value at least 4.1-fold (0.61 log units) from the limit.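

Compound 3 is reported only as a limit in this assay, not as a number: the limit of > 25000 nM in this assay, at which 1 of the 3 values shown sits.

The position now proves sensitive, though the earlier aryl exchange stayed within the scatter: methyl in place of chloro gives an at least 4.0-fold higher number from compound 2 to compound 3 (0.60 log units; beyond the scatter), and 4-methylphenyl in place of naphthalen-1-yl gives an at least 5.2-fold higher number from compound 1 to compound 3 (0.72 log units; beyond the scatter). Exchanging one heavy atom for another, with no hydrogen-bond donor or acceptor entering or leaving, is thus enough to weaken inhibition.

As far as these compounds go, whether this loss is particular to methyl stays open, as does how fluoro, methoxy or an amine would read at this place. The limit also leaves the full size of both steps unknown.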